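Turning One Stereocentre: A Cytotoxicity Question

A few compounds are considered here, and "the series" means these few. Any claim that something is new, unique, unknown or untested is made for them only; others in the source may bear on it.

- compound 1 `COC(=O)C[C@H]1C[C@H](O)[C@@H](C)[C@@H](c2ccc(OC)cc2)N1` gives 5100 nM
- compound 2 `COC(=O)C[C@H]1C[C@@H](O)[C@@H](C)[C@@H](c2ccc(F)cc2)N1` gives 15600 nM

In a functional assay on MCF7 cells (Homo sapiens) for cytotoxicity, read by MTT assay (on this read-out higher numbers stand for weaker inhibition and lower numbers for stronger inhibition), compound 2 has the higher of the two numbers (15600 nM), so it is the weaker inhibitor of the pair. Compound 3 `COC(=O)C[C@H]1C[C@H](O)[C@@H](C)[C@@H](c2ccc(F)cc2)N1` has the same atoms and bonds as compound 2 and differs only in how one centre is drawn (the two compounds have the same atoms and bonds and differ only in configuration as drawn: 1 of 4 stereo elements differ; a stereocentre at a saturated ring carbon is drawn R in compound 2 and S in compound 3). Among the compounds with values here, no measured pair shows the effect of such a change, so its size is uncertain. Compound 1 shows that a lower number is reachable in this small set (5100 nM). The expected change (a 1.6-fold lower number from compound 2 to compound 3 (0.19 log units; within the scatter)) is a modest move toward stronger inhibition, possibly no larger than the scatter. Compound 3 is estimated at 10000 nM (range 4000 nM to 25000 nM).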

Compound 3, half-maximal inhibitory concentration: 18200 nM
Estimate against measurement, compound 3: 1.8-fold (0.26 log units) below, within the range that was stated.
By their numbers in this assay, from the lowest: compound 1; then compounds 2 and 3 (each within the scatter of the next).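

Redrawing the saturated ring carbon from R to S gives a 1.2-fold higher number from compound 2 to compound 3 (0.07 log units; within the scatter), so in this assay this centre makes no readable difference for this pair. That reading is a clean one, and it rests on a single point: the fact that compounds 2 and 3 differ only in the configuration as drawn. The aromatic change does register, since fluoro in place of methoxy on an aromatic carbon gives a 3.6-fold higher number from compound 1 to compound 3 (0.55 log units; beyond the scatter).

Going by these compounds, whether this centre matters as little when methoxy sits on the aromatic ring remains open. So does the effect of an amine or a carboxylic acid on that aromatic carbon.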